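The compounds below may be only part of what the source reports. "The series", "measured", "known", "first", "only" and "open" are said of these compounds alone.

Working notes on the series, centred on the sulfonyl substituent. Going by the values given here, in an ADME assay on a cell-free system (plasma, Rattus norvegicus) (on this read-out higher numbers stand for a larger free fraction and lower numbers for a smaller free fraction), only one number is available: compound 1 (`CN(C)S(=O)(=O)c1ccc(F)c(C#Cc2cc(Cl)ccc2OCC(=O)O)c1`) gives 0.007. Compound 2 (`CC(C)S(=O)(=O)c1ccc(Cl)c(C#Cc2cc(Cl)ccc2OCC(=O)O)c1`), the starting point of this step, has no number, and its entry reads "not determined" (no result reported). Compound 3 (`Cc1ccc(S(=O)(=O)N2CCCCC2C)cc1C#Cc1cc(Cl)ccc1OCC(=O)O`) is in the same position, with the entry "not determined" (no result reported). Among the compounds with values here, compound 2 therefore cannot be ranked against compound 1, and no measured step between any two compounds exists to calibrate the change.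

The next compound to be read is compound 4 (`CS(=O)(=O)c1ccc(Cl)c(C#Cc2cc(Cl)ccc2OCC(=O)O)c1`). The structural change from compound 2 is methyl in place of isopropyl on a sulfonyl sulfur. The rest of the structure stays the same.

With no number for compound 2, the expected step in this assay can only be a judgement. No step beyond the usual scatter is expected, with at most a slight upward drift in the free fraction. Within the data shown here, the only anchor is compound 1 at 0.007, so a small free fraction is expected for compound 4 as well. For compound 4 the estimated unbound fraction is 0.012, with an expected range of 0.005 to 0.03.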

Compound 4, unbound fraction: 0.003
Estimate against measurement, compound 4: 4.0-fold (0.60 log units) above; the whole stated range lies above it.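

Going by these compounds alone, no step from compound 2 to compound 4 can be read: the entry for compound 2 holds no number to set against the result for compound 4. In this assay the compounds shown leave open how the change from isopropylsulfonyl to methylsulfonyl moves the free fraction. No supporting evidence bears on this result.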